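Exchanging the imidazole on the ethoxy linker for triazole

The compounds below may be only part of what the source reports. "The series", "measured", "known", "first", "only" and "open" are said of these compounds alone.

Compound 1 `CCO/C(O)=C1\C(COCCn2ccnc2C)=NC(C)=C(C(=O)OC)C1c1ccccc1Cl`: 2.51 nM in a functional assay (aorta) with Rattus norvegicus as the target; a lower number here means a stronger inhibitor, a higher number a weaker inhibitor
Compound 2 `CCO/C(O)=C1\C(COCCn2nncc2C(N)=O)=NC(C)=C(C(=O)OC)C1c1ccccc1Cl`: 100 nM
Compound 3 `CCO/C(O)=C1\C(COCCN2CC(=O)N=C2N)=NC(C)=C(C(=O)OC)C1c1ccccc1Cl`: 20 nM

Compound 1 holds the lowest of the three numbers shown. Its nearest neighbour comes through the step of an 8.0-fold higher number from compound 1 to compound 3 (0.90 log units; beyond the scatter), and the furthest through a 40-fold higher number from compound 1 to compound 2 (1.60 log units; beyond the scatter). Both replacements of the ring that sits two bonds along the chain from the ether oxygen therefore cost potency, one modestly and one heavily.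

Compound 4 `CCO/C(O)=C1\C(COCCn2ccnn2)=NC(C)=C(C(=O)OC)C1c1ccccc1Cl` is not yet measured. The change from compound 1 is 1H-1,2,3-triazol-1-yl in place of 2-methyl-1H-imidazol-1-yl on a saturated chain carbon, two bonds along the chain from an oxygen on a saturated carbon.

Among the compounds with values here, two measured steps bear on this. The step of a 40-fold higher number from compound 1 to compound 2 (1.60 log units; beyond the scatter) also installs a 1,2,3-triazol-1-yl ring at the same position, though carrying a carbamoyl group, and is large. The step of an 8.0-fold higher number from compound 1 to compound 3 (0.90 log units; beyond the scatter) replaces the same imidazole with a different five-membered ring and is modest. Compound 4 carries the bare triazole without the carbamoyl, so a loss is expected, most likely between those two steps rather than matching the larger one.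

The expected value for compound 4 is 20 nM, with a range from 5 nM to 80 nM. The estimated step is an 8.0-fold higher number from compound 1 to compound 4 (0.90 log units; beyond the scatter).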

Compound 4, half-maximal inhibitory concentration: 15.9 nM
Compound 4: the middle estimate sits 1.3-fold (0.10 log units) above what was measured, within the range that was stated.
By their numbers in this assay, from the lowest: compound 1; then compounds 4 and 3 (each within the scatter of the next); then compound 2.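

In this assay the 1H-1,2,3-triazol-1-yl ring without any substituent still costs potency against 2-methyl-1H-imidazol-1-yl (a 6.3-fold higher number from compound 1 to compound 4 (0.80 log units; beyond the scatter)), so the loss at this position does not depend on the carbamoyl group carried by compound 2. Replacing that carbamoyl with hydrogen on the aromatic carbon gives a further, separate gain (a 6.3-fold lower number from compound 2 to compound 4 (0.80 log units; beyond the scatter)), which divides the large drop seen for compound 2 into a part that goes with the triazole ring and a part that goes with the carbamoyl. The triazole of compound 4 and the non-aromatic ring of compound 3 cannot be told apart here (a 1.3-fold lower number from compound 3 to compound 4 (0.10 log units; within the scatter)), so the data give no preference between these two replacements.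

No measurement shown accounts for any of these steps. Also open, going by these compounds, is whether the advantage of compound 1 lies in the imidazole ring or in its methyl group, a question that an unsubstituted 1H-imidazol-1-yl or a methyl group on the triazole would address, and whether a longer chain or a basic amine such as a dimethylamino group would be tolerated at this position.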